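Replacing a dimethoxyphenyl with fluorophenyl on the shared core

The compounds below may be only part of what the source reports. "The series", "measured", "known", "first", "only" and "open" are said of these compounds alone.

compound 1 `Nc1cc(N)c2nc(-c3ccccc3)c(Oc3ccc(Cl)c(Cl)c3)nc2c1`: < 100000 nM, a limit of the assay rather than a number
compound 2 `Nc1cc(N)c2nc(-c3ccccc3)c(NCc3ccc(Cl)c(Cl)c3)nc2c1`: < 100000 nM, likewise only a limit
compound 3 `COc1ccc(CNc2nc3cc(N)cc(N)c3nc2-c2ccccc2)cc1OC`: 72400 nM

All three were tested in a functional assay on KM12 cells (Homo sapiens) for inhibition, read by sulforhodamine B assay, with a stated time of 48 h; a lower number here means that less compound is tolerated, a higher number that more compound is tolerated. Compound 3 is the only one that yields an actual number; in this assay compound 3 gives 72400 nM. Among the measured compounds shown here, the other two sit at the limit, (the limit of < 100000 nM in this assay, at which 2 of the 3 values shown sit), so the one measured step that touches this position cannot be sized: a step that the limit leaves unreadable from compound 2 to compound 3.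

Compound 4 `Nc1cc(N)c2nc(-c3ccccc3)c(NCc3ccc(F)cc3)nc2c1` has not been measured. It differs from compound 3 in one place: 4-fluorophenyl in place of 3,4-dimethoxyphenyl on a saturated chain carbon bound to a nitrogen on an aromatic ring. Its nearest measured relative is compound 2, which also carries a halogen-bearing ring on that saturated carbon and reports only the limit < 100000 nM. Nothing measured here points to a readable gain.

Compound 4 is therefore expected to give 90000 nM, with a range of 35000 nM to 200000 nM. The expected step from compound 3 to compound 4 is a 1.2-fold higher number from compound 3 to compound 4 (0.09 log units; within the scatter), and a further limit rather than a number is the more likely outcome.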

Compound 4, concentration lethal to 50% of the cells: < 100000 nM
Compound 4: no number, only a limit (the forecaster's own chance of this, stated with the estimate: 55%); the middle value does not contradict the limit.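

Compound 4 gives only a limit, not a number, so the steps to it from compound 1, compound 2 and compound 3 cannot be read: the limit of < 100000 nM in this assay, at which 3 of the 4 values shown sit.

The compounds shown leave open how the 4-fluorophenyl and 3,4-dichlorophenyl compounds truly compare with the 3,4-dimethoxyphenyl compound 3.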